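Bromo in place of methyl on a growth inhibitor

A few compounds are considered here, and "the series" means these few. Any claim that something is new, unique, unknown or untested is made for them only; others in the source may bear on it.

Measured in a functional assay on KB cells (Homo sapiens) for cytotoxicity, read by sulforhodamine B assay; a lower number here means a stronger inhibitor of growth, a higher number a weaker inhibitor of growth:
compound 1 `Cc1ccc2c(c1)CCCN2c1nc(Cl)nc2ccccc12`: 48 nM
compound 2 `Cc1ccc2c(c1)CCCN2c1nc(C)nc2ccccc12`: 204 nM

Of the two, compound 2 has the higher number, so it is the weaker inhibitor of growth. Compound 3 `Cc1nc(N2CCCc3cc(Br)ccc32)c2ccccc2n1` carries bromo in place of methyl on an aromatic carbon. For the measured compounds named here, the only measured step, a 4.3-fold higher number from compound 1 to compound 2 (0.63 log units; beyond the scatter), is modest and also involves methyl, but it sits at a different place in the molecule. It therefore bears only loosely and gives no firm direction, so no step beyond the scatter is expected. The estimated step is a 1.0-fold lower number from compound 2 to compound 3 (0.01 log units; within the scatter). For compound 3 the expected value is 200 nM, within an estimated range of 70 nM to 600 nM.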

Compound 3, concentration for 50% growth inhibition: 178 nM
Compound 3: the middle estimate sits 1.1-fold (0.05 log units) above what was measured; the range from low to high includes it.
By their numbers in this assay, from the lowest: compound 1; then compounds 3 and 2 (each within the scatter of the next).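

In this assay, swapping methyl for bromo at this position gives a 1.1-fold lower number from compound 2 to compound 3 (0.06 log units; within the scatter) and so leaves compound 2 and compound 3 indistinguishable. For the compounds shown here, this is the first view of this position, since the earlier step of a 4.3-fold higher number from compound 1 to compound 2 (0.63 log units; beyond the scatter) concerned another place on the core, where the change went beyond the scatter. No measured evidence bears on why methyl and bromo read alike here.

Going by these compounds, it remains open whether an amine or a carboxylic acid at this position would also leave the number within the scatter. On these data alone, how bromo here would read alongside the chloro of compound 1 is also open.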